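Nitro for Trifluoromethyl Tested on Two Related Cores

The source may hold more compounds than are shown below. What is called first, only, known or untested is meant among the compounds shown, and "the series" means these compounds.

Compound 1 `FC(F)(F)c1ccc(COc2ccc(Nc3ncnc4cc5c(cc34)OCCOCCOCCOCCO5)cc2)cc1` and compound 3 `O=[N+]([O-])c1ccc(COc2ccc(Nc3ncnc4cc5c(cc34)OCCOCCOCCOCCO5)cc2)cc1` share one core, while compound 2 `FC(F)(F)c1ccc(COc2cccc(Nc3ncnc4cc5c(cc34)OCCOCCO5)c2)cc1` and compound 4 `O=[N+]([O-])c1ccc(COc2cccc(Nc3ncnc4cc5c(cc34)OCCOCCO5)c2)cc1` share another; the difference between the two cores is not broken down here. In a functional assay on HepG2 cells (Homo sapiens) for antiproliferative activity, read by MTT assay, with a stated time of 72 h (on this read-out lower numbers stand for stronger inhibition and higher numbers for weaker inhibition), compound 1 gives 3340 nM. Compound 3 gives > 100000 nM, which is a limit of the assay rather than a number. The change between these two, (nitro in place of trifluoromethyl on an aromatic carbon), produced an at least 29-fold higher number from compound 1 to compound 3 (1.47 log units; beyond the scatter), and that step rests on (the limit of > 100000 nM in this assay, at which 2 of the 3 values shown sit). Compound 2 gives > 100000 nM, also a limit of the assay and not a number. Compound 4 carries the same change, (nitro in place of trifluoromethyl on an aromatic carbon), on the other core, and has not yet been measured in this assay. Compound 2 already sits at the limit > 100000 nM, so the expected step that the limit leaves unreadable from compound 2 to compound 4 cannot be resolved as sharply as the earlier one. Compound 4 is expected to give 200000 nM, most probably reported again as a limit, within a range of 100000 nM to 1000000 nM.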

Compound 4, half-maximal inhibitory concentration: 65300 nM
Estimate against measurement, compound 4: 3.1-fold (0.49 log units) above; measured number outside the range, below it.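

In this assay, putting nitro in place of trifluoromethyl gave an at least 1.5-fold lower number from compound 2 to compound 4 (0.18 log units; that floor lies within the scatter), and that floor alone does not establish a real gain. Even so, the change did not behave alike on the two cores, so its effect on one core cannot simply be carried over to the other: the same change on two cores in this assay, an at least 29-fold higher number (1.47 log units; beyond the scatter) from compound 1 to compound 3 and an at least 1.5-fold lower number (0.18 log units; that floor lies within the scatter) from compound 2 to compound 4, at least 45-fold (1.66 log units) apart, beyond the scatter of two such steps What this does not show is the true size of either step, as each one rests on a limit of the assay rather than on two measured numbers: the limit of > 100000 nM in this assay, at which 2 of the 4 values shown sit.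

The compounds shown leave open which of the differences between the two cores decides how the change turns out, since only one pair stands on each core. They also leave open how other groups in place of the trifluoromethyl, such as a nitrile, an amine or a carboxylic acid, would read in this assay on either core.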